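Methoxy in Place of Chloro, Starting from a Limit

A few compounds are considered here, and "the series" means these few. Any claim that something is new, unique, unknown or untested is made for them only; others in the source may bear on it.

Compound 1 (`Cc1cc(NC(=O)Nc2ccc(Cl)c(Cl)c2)c2ccccc2n1`) gives > 25000 nM in an ADME assay on HEK293 cells (Homo sapiens) for cytotoxicity, with a stated time of 72 h (a lower number here means that less compound is needed, a higher number that more compound is needed for the effect), and that value is a limit, not a number. Compound 1 thus stands at the limit of > 25000 nM in this assay, at which 1 of the 2 values shown sits, for now. Compound 2 (`CSc1ccc(NC(=O)Nc2cc(C)nc3ccccc23)cc1`) gives 24000 nM in this assay as a true number. Compound 3 (`COc1ccc(NC(=O)Nc2cc(C)nc3ccccc23)cc1Cl`) carries methoxy in place of chloro on an aromatic carbon ortho to a chloro group and para to a large group. For the measured compounds named here, no measured step speaks to this change, so none beyond the scatter is expected in this assay here. The expected a number no higher from compound 1 to compound 3 (the limit leaves the size open) would therefore stay small. Compound 3 is estimated at 25000 nM with a range from 13000 nM to 50000 nM in this assay.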

Compound 3, half-maximal effective concentration: 26000 nM
Compound 3: the middle estimate sits 1.0-fold (0.02 log units) below what was measured; the range from low to high includes it.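

Compound 1 carries only a limit in this assay, and no new step can be read from compound 1 to compound 3. The compounds shown leave open what methoxy in place of chloro on an aromatic carbon does to the value in this assay.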